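The source may hold more compounds than are shown below. What is called first, only, known or untested is meant among the compounds shown, and "the series" means these compounds.

Measured compounds:
Compound 1 `COc1cc[nH]c1/C=C1\C(=O)Nc2ccc([N+](=O)[O-])c(N[C@H]3CC[C@H](O)CC3)c21` gives 8550 nM in a functional assay on MDA-MB-435 cells (Homo sapiens) for antiproliferative activity, read by MTT assay, with a stated time of 5 days; a lower number here means a stronger inhibitor, a higher number a weaker inhibitor.
Compound 2 `COc1cc[nH]c1/C=C1\C(=O)Nc2ccc([N+](=O)[O-])c(N[C@H]3CC[C@H](N)C3)c21` gives 61 nM in this assay.
Compound 3 `COc1cc[nH]c1/C=C1\C(=O)Nc2ccc([N+](=O)[O-])c(N3CCCC(CO)C3)c21` gives 441 nM in this assay.

Compound 1 has the highest number of the three, so it is the weakest inhibitor of this small set, and the steps from it to the other two, a 140-fold lower number from compound 1 to compound 2 (2.15 log units; beyond the scatter) and a 19-fold lower number from compound 1 to compound 3 (1.29 log units; beyond the scatter), both lie well beyond the scatter. Compound 4 `COc1cc[nH]c1/C=C1\C(=O)Nc2ccc([N+](=O)[O-])c(N3CCCC(O)C3)c21` has not yet been measured. It differs from compound 1 in one place: 3-hydroxypiperidin-1-yl in place of (4-hydroxycyclohexyl)amino on an aromatic carbon. The closest measured guide is the step to compound 3, where a 3-(hydroxymethyl)piperidin-1-yl group took the place of the same (4-hydroxycyclohexyl)amino group and the number fell sharply, a 19-fold lower number from compound 1 to compound 3 (1.29 log units; beyond the scatter). The step to compound 2, a 140-fold lower number from compound 1 to compound 2 (2.15 log units; beyond the scatter), shows that a different replacement at the same position also lowered the number. Both point the same way, so a large fall is expected for compound 4, a 14-fold lower number from compound 1 to compound 4 (1.15 log units; beyond the scatter), though its exact size cannot be fixed from so few examples. The estimate for compound 4 is 600 nM, with a likely range from 200 nM to 2500 nM.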

Compound 4, half-maximal inhibitory concentration: 250 nM
Estimate against measurement, compound 4: 2.4-fold (0.38 log units) above; the measured number falls inside the stated range.
By their numbers in this assay, from the lowest: compound 2; then compounds 4 and 3 (each within the scatter of the next); then compound 1.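

In this assay the large fall seen with compound 3 does not depend on the hydroxymethyl group: the 3-hydroxypiperidin-1-yl group also lowers the number (a 34-fold lower number from compound 1 to compound 4 (1.53 log units; beyond the scatter)), and putting hydroxy in place of hydroxymethyl on the saturated ring carbon stays within the scatter (a 1.8-fold lower number from compound 3 to compound 4 (0.25 log units; within the scatter)). Even so, the hydroxypiperidine does not reach compound 2, which carries a (3-aminocyclopentyl)amino group at this aromatic carbon (a 4.1-fold higher number from compound 2 to compound 4 (0.61 log units; beyond the scatter)). No measured evidence here explains any of these differences.

Compound 2 differs from compound 4 in its ring, its amine and its linking nitrogen together, so the compounds shown cannot tell which of these goes with its lower number. As far as these compounds go, a 3-aminopiperidin-1-yl group would bear on that question, while a longer chain such as 2-hydroxyethyl on the piperidine ring remains unexplored here.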